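Amide variation on a weakly antiproliferative scaffold

The compounds below may be only part of what the source reports. "The series", "measured", "known", "first", "only" and "open" are said of these compounds alone.

Measured so far:
- compound 1 `O=C(Nc1ccc(Cl)c(-c2nnc3c(Cl)cccn23)c1)c1ccccc1` gives 73500 nM
- compound 2 `O=C(Nc1ccc(Cl)c(-c2nnc3c(Cl)cccn23)c1)c1ccc(Cl)cc1` reaches only an assay limit, > 100000 nM
- compound 3 `O=C(Nc1ccc(Cl)c(-c2nnc3c(Cl)cccn23)c1)c1ccon1` reaches only an assay limit, > 100000 nM

All three compounds share one core and differ only in the group on the amide carbonyl. In a functional assay on U-251 cells (Homo sapiens) for antiproliferative activity, read by MTT assay, with a stated time of 72 h (on this read-out higher numbers stand for weaker inhibition and lower numbers for stronger inhibition), compound 1 gives 73500 nM. For compound 2 the result is a limit of the assay, not a number, at > 100000 nM. Compound 3 likewise gives only a limit, > 100000 nM. Compound 3 therefore stands at the upper edge of what this assay reports, and the same is true of the limit of > 100000 nM in this assay, at which 2 of the 3 values shown sit. The measured steps are small or unreadable: an at least 1.3-fold higher number from compound 1 to compound 2 (0.13 log units; that floor lies within the scatter), an at least 1.3-fold higher number from compound 1 to compound 3 (0.13 log units; that floor lies within the scatter), and a step that the two limits leave unreadable from compound 2 to compound 3.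

Compound 4 `O=C(Nc1ccc(Cl)c(-c2nnc3c(Cl)cccn23)c1)c1ccc(F)cc1Cl` carries a 2-chloro-4-fluorophenyl on the carbonyl carbon; the change from compound 3 is 2-chloro-4-fluorophenyl in place of 1,2-oxazol-3-yl on a carbonyl carbon. The closest comparison is compound 2, whose 4-chlorophenyl amide also sits at the limit, and compound 1, whose plain phenyl amide is only modestly below it. For compound 4, then, no step beyond the scatter is expected; the estimated step is a number no higher from compound 3 to compound 4 (the limit leaves the size open). The expected value for compound 4 in this assay is 100000 nM, within 50000 nM to 200000 nM, and a further limit rather than a number is quite likely.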

Compound 4, half-maximal inhibitory concentration: > 100000 nM
Compound 4: only a limit was reported; the forecaster's own chance of this, stated with the estimate: 60%; the middle value sits exactly at the limit.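

With 2-chloro-4-fluorophenyl on the carbonyl carbon, this position now holds a phenyl ring carrying two halogens, yet in this assay compound 4 gives > 100000 nM, which is a limit of the assay and not a number. Within the data shown here, the one step that can be read is an at least 1.3-fold higher number from compound 1 to compound 4 (0.13 log units; that floor lies within the scatter), so compound 4 cannot be told apart from the plain phenyl amide, and the steps to compound 2 and compound 3 cannot be read at all. Compound 1 is the only one of these amides to give a number, and the new result extends the cluster at one edge of the read-out, whether the group is a substituted phenyl or 1,2-oxazol-3-yl: the limit of > 100000 nM in this assay, at which 3 of the 4 values shown sit.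

On these data alone, whether compound 2, compound 3 and compound 4 differ from one another remains unknown, since all three stop at the same limit. Every group shown on this carbonyl carbon is a single aromatic ring, so it remains open whether a non-aromatic group, such as a piperidine ring or a short chain ending in an amine or a carboxylic acid, would give a value well clear of that limit.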